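Tert-Butoxycarbonyl Capping of an Amine Chain on Two Cores

A few compounds are considered here, and "the series" means these few. Any claim that something is new, unique, unknown or untested is made for them only; others in the source may bear on it.

Measured compounds in an assay on HEK293 cells for inhibition of Voltage-dependent T-type calcium channel subunit alpha-1G (Homo sapiens); a higher number here means a weaker inhibitor, a lower number a stronger inhibitor:
compound 1, `COC(=O)CC1c2ccccc2N=C(Nc2ccccc2)N1CCCCCN`, 9160 nM
compound 2, `COC(=O)CC1c2ccccc2N=C(Nc2ccccc2)N1CCCCCNC(=O)OC(C)(C)C`, 2270 nM
compound 3, `COC(=O)CC1c2ccccc2N=C(NCCCCCN)N1c1ccccc1`, 1840 nM

Compound 2 differs from compound 1 by tert-butoxycarbonyl in place of hydrogen on an amine nitrogen, and in this assay this change gave a 4.0-fold lower number from compound 1 to compound 2 (0.61 log units; beyond the scatter). Compound 3 has the same atoms as compound 1 joined differently; the difference between the two cores is not broken down here. Compound 3 gives a number within the scatter of compound 2 and beyond the scatter from compound 1.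

Compound 4, `COC(=O)CC1c2ccccc2N=C(NCCCCCNC(=O)OC(C)(C)C)N1c1ccccc1`, has not yet been measured in this assay. It differs from compound 3 by tert-butoxycarbonyl in place of hydrogen on an amine nitrogen, the same change that separates compound 1 from compound 2, at the same kind of place.

The step from compound 3 to compound 4 is expected to be a 2.6-fold lower number from compound 3 to compound 4 (0.42 log units; beyond the scatter) because the same change gave a 4.0-fold lower number from compound 1 to compound 2 (0.61 log units; beyond the scatter); the smaller size allows for the lower starting number of compound 3. Compound 4 is therefore estimated at 700 nM, with a range from 300 nM to 1800 nM.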

Compound 4, half-maximal inhibitory concentration: 2020 nM
The estimate for compound 4 lay 2.9-fold (0.46 log units) below the measured number, outside the stated range (above it).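

In this assay, tert-butoxycarbonyl in place of hydrogen on the amine nitrogen gave a 1.1-fold higher number from compound 3 to compound 4 (0.04 log units; within the scatter), so the capping that had moved the number on the core of compound 1 left it within the scatter on the core of compound 3. The change did not keep its size when carried from one core to the other: the same change on two cores in this assay, a 4.0-fold lower number (0.61 log units; beyond the scatter) from compound 1 to compound 2 and a 1.1-fold higher number (0.04 log units; within the scatter) from compound 3 to compound 4, 4.4-fold (0.65 log units) apart, beyond the scatter of two such steps In this series, then, a step seen on one of these cores cannot be assumed on the other, but with a single pair on each core the result does not show why the two differ or how the change would behave on any further core.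

As far as these compounds go, it remains open whether an acetyl group on the same amine nitrogen, or a shorter or longer chain carrying it, would follow the pattern of compound 2 or that of compound 4. Also open, from the compounds shown here alone, is how a carboxylic acid in place of the methyl ester would behave on either core.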